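The source may report more compounds than this note shows. Statements on the series, on what has been measured and on what is new or still open speak of the compounds shown alone.

In an in vivo functional assay on the whole organism for inhibition, with Rattus norvegicus as the target (a lower number here means that less compound is needed, a higher number that more compound is needed for the effect), the measured compounds stand as follows:

compound 1 `CCCCc1nc(CCC)c(CCC(=O)OCC)c(=O)n1Cc1ccc(-c2ccccc2-c2nnn[nH]2)cc1`: "not determined" (no result reported)
compound 2 `CCCCc1nc(C)c(CC(=O)N2CCSCC2)c(=O)n1Cc1ccc(-c2ccccc2-c2nnn[nH]2)cc1`: 0.038 mg/kg

For the measured compounds named here, compound 2 carries the only number in this assay, at 0.038 mg/kg, so it can be ranked against no other compound. Compound 1 has no reported result. Compound 3 `CCCCc1nc(C)c(CCC(=O)N2CCCCC2)c(=O)n1Cc1ccc(-c2ccccc2-c2nnn[nH]2)cc1` departs from compound 2 in one place, with ((piperidin-1-yl)carbonyl)methyl in place of (thiomorpholin-4-yl)carbonyl on a saturated chain carbon bound to an aromatic carbon. Going by the values given here, no measured pair shows what a change of this kind does, so the expectation is only loosely grounded. A modest move towards a higher dose is expected, and the estimated size is a 2.1-fold higher number from compound 2 to compound 3 (0.32 log units; beyond the scatter). For compound 3 the estimated dose is 0.08 mg/kg, with an expected range from 0.02 mg/kg to 0.3 mg/kg.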

Compound 3, dose for half-maximal effect: 0.164 mg/kg
Beside the measured number, compound 3's estimate is 2.1-fold (0.31 log units) below it; the measured number falls inside the stated range.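

In this assay, the change at this position gives a 4.3-fold higher number from compound 2 to compound 3 (0.64 log units; beyond the scatter), the first measured sign that the dose responds to the group on this saturated chain carbon. The effect is weakened but not lost with ((piperidin-1-yl)carbonyl)methyl in place of (thiomorpholin-4-yl)carbonyl. Read one bond further out, the step from ((thiomorpholin-4-yl)carbonyl)methyl to 2-((piperidin-1-yl)carbonyl)ethyl alters both the ring and the chain, and no measurement at hand accounts for the shift.

The compounds shown leave open how much of the step belongs to the ring and how much to the chain, a question that a 2-((thiomorpholin-4-yl)carbonyl)ethyl or a ((piperidin-1-yl)carbonyl)methyl group on the shared core would separate. They also leave open how a morpholine amide or a free carboxylic acid would behave at this position.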